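The compounds below may be only part of what the source reports. "The series", "measured", "known", "first", "only" and "open" are said of these compounds alone.

Compound 1 `CC(C)Oc1ccc(CNC(=O)c2ccc(C(C)(C)C)cc2)cc1` gives 170 nM in an assay on HeLa cells with Bile acid receptor (Homo sapiens) as the target, read by a luciferase reporter, with a stated time of 24 h; a higher number here means that more compound is needed for the effect, a lower number that less compound is needed.
Compound 2 `O=C(O)c1ccc(CNC(=O)c2ccc3ccccc3c2)cc1` gives 1360 nM in this assay.
Compound 3 `CC(C)(C)c1ccc(C(=O)NCc2ccc(N)cc2Cl)cc1` gives 46 nM in this assay.

Among the three compounds measured, compound 1 stands with the second highest number. Compound 3 is its nearest neighbour and lies beyond the scatter below it; compound 2 is furthest and lies beyond the scatter above it. Compound 1 thus sits between a stronger and a weaker member of this small set, without any directly comparable pair that would show how one isolated change shifts the read-out.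

Compound 4 `CC(=O)c1ccc(CNC(=O)c2ccc(C(C)(C)C)cc2)cc1` keeps the shared core of compound 1 and differs from it in one place only: acetyl in place of isopropoxy on an aromatic carbon. Going by the values given here, no measured pair tracks exactly this kind of exchange, so the expectation for compound 4 rests on the position of compound 1 alone and on the general spread of the three numbers.

The account therefore expects a modest step in this assay, tending toward a higher number, one that may fall within the usual scatter or slightly beyond it; a step of a 2.4-fold higher number from compound 1 to compound 4 (0.37 log units; beyond the scatter) is the estimate. For compound 4 the estimated value in this assay is 400 nM, expected to lie between 120 nM and 1300 nM.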

Compound 4, half-maximal effective concentration: 100 nM
For compound 4 the middle estimate is 4.0-fold (0.60 log units) above the measured one; measured number outside the range, below it.
By their numbers in this assay, from the lowest: compound 3; then compounds 4 and 1 (each within the scatter of the next); then compound 2.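

In this assay, going by these compounds alone, acetyl in place of isopropoxy on an aromatic carbon, para to a large group, gives a 1.7-fold lower number from compound 1 to compound 4 (0.23 log units; within the scatter), and this is the first pair in the set that isolates a single change. At this place, the read-outs of the two compounds cannot be told apart, although the shared core carries a different group. The two groups match in their counts of hydrogen-bond donors and acceptors, and neither has a ring or a net charge, while acetyl alone brings a double bond outside the aromatic ring; no measurement shown here explains why the two read alike.

The compounds shown leave open whether a nitrile or a longer chain such as butoxy at this same place on the core of compound 1 would also stay within the scatter, or whether either would move the number clearly in one direction. This single pair also cannot show whether acetyl in place of isopropoxy would read the same way on a different core.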